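Working notes: 4-methylphenyl to phenyl from compound 1

The source may report more compounds than this note shows. Statements on the series, on what has been measured and on what is new or still open speak of the compounds shown alone.

- compound 1 `Cc1ccc(S(=O)(=O)N/N=C2\C(=O)Nc3ccc(S(=O)(=O)N4CCOCC4)cc32)cc1` gives 23400 nM
- compound 2 `O=C1Nc2ccc(S(=O)(=O)N3CCOCC3)cc2/C1=N/c1ccc(/N=C2\C(=O)Nc3ccc(S(=O)(=O)N4CCOCC4)cc32)cc1` gives 7480 nM
- compound 3 `O=C1Nc2ccc(S(=O)(=O)N3CCOCC3)cc2/C1=N/c1ccc(C(=O)O)cc1` gives 23600 nM

In a functional assay on HCT-116 cells (Homo sapiens) for cytotoxicity, read by sulforhodamine B assay, with a stated time of 24 h (a higher number here means a weaker inhibitor, a lower number a stronger inhibitor), compound 1 stands level with compound 3 within the scatter, while compound 2 has a lower number than compound 1 by more than the scatter.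

Compound 4 `O=C1Nc2ccc(S(=O)(=O)N3CCOCC3)cc2/C1=N/NS(=O)(=O)c1ccccc1` has not yet been measured. Its difference from compound 1 is hydrogen in place of methyl on an aromatic carbon (hydrogen in place of methyl on an aromatic carbon, 4-methylphenyl to phenyl). For the measured compounds named here, the series holds no measured pair that carries this change alone. The expectation therefore rests on compound 1 at 23400 nM and on the small size of the change, with no step beyond the scatter expected in this assay in either direction. The estimated step of a 1.1-fold lower number from compound 1 to compound 4 (0.03 log units; within the scatter) stays within the scatter of repeated measurements. Compound 4 is expected at 22000 nM with an estimated range from 11000 nM to 45000 nM as the working figure.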

Compound 4, half-maximal inhibitory concentration: 13300 nM
Compound 4: middle estimate off by 1.7-fold (0.22 log units), on the high side; measured number inside the range.
By their numbers in this assay, from the lowest: compounds 2, 4, 1 and 3 (each within the scatter of the next, the first and the last beyond it).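

In this assay, the series now holds a single-place step at the aromatic carbon para to a large group: hydrogen in place of methyl gives a 1.8-fold lower number from compound 1 to compound 4 (0.25 log units; within the scatter), so this exchange on the phenylsulfonyl ring does not separate the two compounds. The change on the double-bonded nitrogen, (phenylsulfonyl)amino in place of 4-carboxyphenyl, gives a 1.8-fold lower number from compound 3 to compound 4 (0.25 log units; within the scatter), so these two quite different groups also stay level in this assay. No measurement bears on either step, and neither can be explained from the data at hand.

Still open, from the compounds shown here alone, is whether a larger or different group at the same aromatic carbon, such as a methoxy, a chlorine or an amine, would move the number beyond the scatter. Only hydrogen and methyl have been compared at this place, so the tolerance seen covers those two groups alone.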